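Methoxy at the Ring Carbon: Estimating Compound 3

The compounds below may be only part of what the source reports. "The series", "measured", "known", "first", "only" and "open" are said of these compounds alone.

Measured compounds:
- Compound 1, `C=C1CC[C@H](C)[C@@](C)(CCC2=CC(O)OC2=O)C/C=C\C=C/1C(=O)O`: 4100 nM
- Compound 2, `C=C1CC[C@H](C)[C@@](C)(CCC2=CCOC2=O)C/C=C\C=C/1C(=O)O`: 14000 nM

Compound 2 gives the highest number of the two measured compounds in an assay on isolated protein (strain Wistar) for inhibition of Voltage-gated L-type calcium channel (Rattus norvegicus); on this read-out higher numbers stand for an effect only at larger amounts of compound and lower numbers for an effect already at smaller amounts; its nearest neighbour is compound 1 with 4100 nM. Going by the values given here, the only measured step is a 3.4-fold higher number from compound 1 to compound 2 (0.53 log units; beyond the scatter), a hydrogen in place of hydroxy on a saturated ring carbon, which moved the number up by a modest amount.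

Compound 3, `C=C1CC[C@H](C)[C@@](C)(CCC2=CC(OC)OC2=O)C/C=C\C=C/1C(=O)O`, has not yet been measured. It differs from compound 2 by methoxy in place of hydrogen on a saturated ring carbon, at the same saturated ring carbon of the five-membered non-aromatic ring with one oxygen, next to the ring oxygen, where compound 1 carries hydroxy and compound 2 carries hydrogen.

The step from compound 1 to compound 2 is the one that bears on this change: removing the oxygen-bearing group there raised the number. Restoring an oxygen-bearing group in the form of methoxy is therefore expected to move the number back down, by roughly the same modest size, so compound 3 is estimated to land near compound 1, with a 2.8-fold lower number from compound 2 to compound 3 (0.45 log units; beyond the scatter). The estimate for compound 3 is 5000 nM, with a range from 2000 nM to 14000 nM.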

Compound 3, half-maximal effective concentration: 22000 nM
The estimate for compound 3 lay 4.4-fold (0.64 log units) below the measured number; the measured number lies above the stated range.
By their numbers in this assay, from the lowest: compound 1; then compounds 2 and 3 (each within the scatter of the next).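

In this assay, methoxy on this saturated ring carbon does not act as hydroxy does: a 1.6-fold higher number from compound 2 to compound 3 (0.20 log units; within the scatter) shows that methoxy in place of hydrogen leaves the read-out indistinguishable from that of compound 2. With methyl in place of the hydrogen on the oxygen of compound 1, the result is a 5.4-fold higher number from compound 1 to compound 3 (0.73 log units; beyond the scatter) and the lower number of compound 1 is lost, so among these three compounds it goes with hydroxy alone and not with any oxygen-bearing group at this carbon. Nothing available explains why hydroxy and methoxy part ways here.

The three compounds leave open whether other groups at this carbon, such as an amine or ethoxy, would fall with compound 1 or with compounds 2 and 3. Going by these compounds alone, they also cannot separate what losing the hydrogen on the oxygen contributes from what gaining the methyl contributes, since the two changes come together in the single step between compound 1 and compound 3.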